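Chloro for fluoro in a narrow series

A few compounds are considered here, and "the series" means these few. Any claim that something is new, unique, unknown or untested is made for them only; others in the source may bear on it.

Three measured compounds share one core and differ only in the group on the carbonyl. In a functional assay on A549 cells (Homo sapiens) for antiproliferative activity, read by MTT assay, with a stated time of 48 h (a higher number here means a weaker inhibitor, a lower number a stronger inhibitor), compound 1 `COc1ccc(/C=C/c2cc(OC)cc(OC)c2/C=C/C(=O)c2ccc(C)cc2)cc1` gives 3.6 ug/mL, compound 2 `COc1ccc(/C=C/c2cc(OC)cc(OC)c2/C=C/C(=O)c2cccc(Cl)c2)cc1` gives 5.6 ug/mL and compound 3 `COc1ccc(/C=C/c2cc(OC)cc(OC)c2/C=C/C(=O)c2ccc(F)cc2)cc1` gives 6.6 ug/mL. Compound 3 lies within the scatter of both others, so these numbers cannot be ranked.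

Compound 4 `COc1ccc(/C=C/c2cc(OC)cc(OC)c2/C=C/C(=O)c2ccc(Cl)cc2)cc1` differs from compound 3 by one swap: chloro in place of fluoro on an aromatic carbon.

Going by the values given here, three measured steps bear on it. Fluoro in place of methyl gave a 1.8-fold higher number from compound 1 to compound 3 (0.26 log units; within the scatter). Going from 3-chlorophenyl to 4-fluorophenyl gave a 1.2-fold higher number from compound 2 to compound 3 (0.07 log units; within the scatter), and 3-chlorophenyl in place of 4-methylphenyl gave a 1.6-fold higher number from compound 1 to compound 2 (0.19 log units; within the scatter). None of these three steps left the scatter, so no clear direction can be drawn from them, and a change beyond the scatter is not expected here.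

The expected step is a 1.2-fold lower number from compound 3 to compound 4 (0.08 log units; within the scatter), which would be too small to distinguish from repeat scatter. For compound 4 the estimated value is 5.5 ug/mL, with an expected range from 3 ug/mL to 10 ug/mL.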

Compound 4, half-maximal inhibitory concentration: 6.4 ug/mL
Estimate against measurement, compound 4: 1.2-fold (0.07 log units) below, within the range that was stated.
By their numbers in this assay, from the lowest: compounds 1, 2, 4 and 3 (each within the scatter of the next).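

At this place on the ring, para to a large group, chloro in place of fluoro gives a 1.0-fold lower number from compound 3 to compound 4 (0.01 log units; within the scatter) in this assay, so exchanging one halogen for the other here leaves no readable difference. The other two new comparisons also stay within the scatter: 4-chlorophenyl in place of 3-chlorophenyl gives a 1.1-fold higher number from compound 2 to compound 4 (0.06 log units; within the scatter) and chloro in place of methyl gives a 1.8-fold higher number from compound 1 to compound 4 (0.25 log units; within the scatter) in the same assay, so neither moving the chloro nor replacing the methyl separates these compounds. No evidence is available that could explain these results.

As far as these compounds go, whether an amine, a carboxylic acid or a longer chain such as butyl at this place would move the number beyond the scatter remains open. So does whether this flat picture would hold on a different core or in other cell lines.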